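Chloro for the amine side chain on an allyloxy core

The source may hold more compounds than are shown below. What is called first, only, known or untested is meant among the compounds shown, and "the series" means these compounds.

Three compounds have numbers in a functional assay on HepG2 cells (Homo sapiens) for cytotoxicity, read by MTT assay, with a stated time of 48 h; on this read-out higher numbers stand for weaker inhibition and lower numbers for stronger inhibition. Compound 1 `CN(C)CCNc1ccnc2cc(OCc3ccc(F)cc3)ccc12` gives 790 nM; compound 2 `CCCCOc1ccc2c(Cl)ccnc2c1` gives 2640 nM; compound 3 `C=CCOc1ccc2c(NCCN(C)C)ccnc2c1` gives 1660 nM. Compound 3 stands second highest of the three, within the scatter of compound 2 and beyond it from compound 1. Within the data shown here, the only step between measured compounds, a 2.1-fold higher number from compound 1 to compound 3 (0.32 log units; beyond the scatter), concerns the ether end and does not bear on the change now followed. Compound 4 `C=CCOc1ccc2c(Cl)ccnc2c1` differs from compound 3 by chloro in place of (2-(dimethylamino)ethyl)amino on an aromatic carbon. Among the measured compounds shown here, no measured step covers this exchange; compound 2, which carries chloro on another ether, shows a number within the scatter of compound 3. Compound 4 is therefore expected near compound 2, a step of a 1.6-fold higher number from compound 3 to compound 4 (0.19 log units; within the scatter), with an estimate of 2600 nM and a range from 1000 nM to 7000 nM.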

Compound 4, half-maximal inhibitory concentration: 2770 nM
Compound 4: middle estimate off by 1.1-fold (0.03 log units), on the low side, within the range that was stated.
By their numbers in this assay, from the lowest: compound 1; then compounds 3, 2 and 4 (each within the scatter of the next).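

The exchange of (2-(dimethylamino)ethyl)amino for chloro on this aromatic carbon, opposite the ring nitrogen, gives a 1.7-fold higher number from compound 3 to compound 4 (0.22 log units; within the scatter) in this assay, so the whole side chain leaves without a change that clears the scatter. With chloro in place, vinyl for propyl at the ether end gives a 1.0-fold higher number from compound 2 to compound 4 (0.02 log units; within the scatter), and the two chloro compounds cannot be told apart. No supporting data bear on the reason for either result. Still open, on these data alone, is whether a piperazine or a longer amine chain at this carbon would keep the number in this range. Also open, as far as these compounds go, is whether the 4-fluorophenyl ether end of compound 1 would hold its number with chloro at this carbon.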